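Swapping a Saturated Side Chain for a Dimethylisoxazole

The compounds below may be only part of what the source reports. "The series", "measured", "known", "first", "only" and "open" are said of these compounds alone.

For the measured compounds named here, compound 1 `Cc1cc(C)c(CN2CCc3c(Cl)cc([C@H](CO)[C@H]4CCOC4)c(Cl)c3C2=O)c(=O)[nH]1` is the only compound here with a single figure in an assay on cells for inhibition of histone-lysine N-methyltransferase EZH2 (Homo sapiens), read by ELISA, with a stated time of 72 h (on this read-out lower numbers stand for stronger inhibition and higher numbers for weaker inhibition), where compound 1 gives 10 nM; one further entry for it carries no single number. Compound 2 `COC(c1cc(Cl)c2c(c1Cl)C(=O)N(Cc1c(C)cc(C)[nH]c1=O)CC2)C1CCN(C2COC2)CC1` spreads widely across its entries in this assay, giving 1310 nM; 16 nM (2 entries). Compound 3 `Cc1cc(C)c(CN2CCc3c(Cl)cc(-c4c(C)noc4C)c(Cl)c3C2=O)c(=O)[nH]1` differs from compound 1 by a group of 7 heavy atoms (5 carbon, 1 nitrogen, 1 oxygen; one five-membered aromatic ring with 2 hetero atoms) in place of a group of 8 heavy atoms (6 carbon, 2 oxygen; one five-membered non-aromatic ring with 1 hetero atom), on an aromatic carbon. Going by the values given here, no measured step matches this change, so the expected step from compound 1 to compound 3 in this assay, a 4.0-fold higher number from compound 1 to compound 3 (0.60 log units; beyond the scatter), is a modest loss that may still sit within the scatter. Compound 3 is therefore expected to give 40 nM, within 8 nM to 200 nM.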

Compound 3, half-maximal inhibitory concentration: 17 nM
Beside the measured number, compound 3's estimate is 2.4-fold (0.37 log units) above it, within the range that was stated.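

In this assay, placing 3,5-dimethyl-1,2-oxazol-4-yl on this aromatic carbon in place of the side chain with its five-membered non-aromatic ring gives a 1.7-fold higher number from compound 1 to compound 3 (0.23 log units; within the scatter). The entering group has no hydrogen-bond donor and no defined stereocentre, so this pair shows that the number can hold without either. Single entries deserve caution, as entries for one compound can lie far apart in this assay: the several entries of compound 2 in this assay, 1310 nM; 16 nM (2 entries)

On these data alone, whether a phenyl ring, an amine or a carboxylic acid would hold the number at this position remains open.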